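Ethoxy on compound 2: a modest rise expected

The compounds below may be only part of what the source reports. "The series", "measured", "known", "first", "only" and "open" are said of these compounds alone.

In a functional assay on PC-3 cells (Homo sapiens) for cytotoxicity (a lower number here means a stronger inhibitor, a higher number a weaker inhibitor), compound 1 (`COc1ccc2nc(NC(=O)CCCCC(=O)NO)sc2c1`) gives 15.3 ug/mL and compound 3 (`Cc1ccc2nc(NC(=O)CCCCC(=O)NO)sc2c1`) gives 6.23 ug/mL as its reading. In this assay compound 2 (`O=C(CCCCCCC(=O)Nc1nc2ccccc2s1)NO`) gives 5.44 ug/mL and so stands level with compound 3 within the scatter, while compound 1 lies clearly higher than both. Compound 4 (`CCOc1ccc2nc(NC(=O)CCCCCCC(=O)NO)sc2c1`) differs from compound 2 by a single change (ethoxy in place of hydrogen on an aromatic carbon) with ethoxy in place of hydrogen on an aromatic carbon. Within the data shown here, one measured step bears on this, and only indirectly: the reading shows a 2.5-fold lower number from compound 1 to compound 3 (0.39 log units; beyond the scatter) when methyl replaces methoxy. That step is modest, and compound 1 and compound 3 carry a different chain from compound 2. Among the measured compounds shown here, no measured pair sets ethoxy or methoxy against hydrogen. Read in reverse, the step from compound 1 points upward, so a modest rise of similar size is expected, and the estimated change is a 1.7-fold higher number from compound 2 to compound 4 (0.24 log units; within the scatter) in this assay with only this thin support. For compound 4 the estimated value is 9.5 ug/mL with 4 ug/mL to 22 ug/mL as its range.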

Compound 4, half-maximal inhibitory concentration: 16.9 ug/mL
Estimate against measurement, compound 4: 1.8-fold (0.25 log units) below, within the range that was stated.
By their numbers in this assay, from the lowest: compounds 2 and 3 (each within the scatter of the next); then compounds 1 and 4 (each within the scatter of the next).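

With the chain of compound 2 kept, placing ethoxy on this aromatic carbon in this assay gives a 3.1-fold higher number from compound 2 to compound 4 (0.49 log units; beyond the scatter), a rise beyond the scatter. Among these compounds, this is the first direct reading of a substituent against hydrogen at this position: the earlier compounds set only methyl against methoxy, and on a different chain. No measurement offered here accounts for the rise.

The compounds shown leave open whether the rise belongs to ethoxy alone or would also appear with methyl, chlorine or an amine on the same carbon of this chain. They also leave open how the unsubstituted core would read on the chain of compound 1, and so whether hydrogen would stand apart from methoxy and methyl there too.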